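The source may report more compounds than this note shows. Statements on the series, on what has been measured and on what is new or still open speak of the compounds shown alone.

Measured so far in a functional assay on MDA-MB-231 cells (Homo sapiens) for inhibition, read by sulforhodamine B assay, with a stated time of 48 h, tested at 10 uM; on this read-out higher numbers stand for a weaker effect at the one concentration tested and lower numbers for a stronger effect:
compound 1 `COc1cc2cc(Oc3ccc(NC(=O)Nc4ccccc4)cc3)c(C)nc2cc1OC` — 80%
compound 2 `COc1cc2cc(Oc3ccc(NC(=O)Nc4cccc(C(F)(F)F)c4)cc3)c(C)nc2cc1OC` — -8.32%

Within the data shown here, compound 2 stands lowest of the two numbers measured in this assay; its nearest neighbour is compound 1, and the single one-place step between them, a number 88.3 percentage points lower from compound 1 to compound 2 (beyond the scatter), is large and beyond the scatter.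

Compound 3 `COc1cc2cc(Oc3ccc(NC(=O)Nc4ccc(Cl)c(Cl)c4)cc3)c(C)nc2cc1OC` has not been measured. It differs from compound 2 in one place: 3,4-dichlorophenyl in place of 3-(trifluoromethyl)phenyl on an amide-type nitrogen. Among the measured compounds shown here, no measured step covers this change. For the measured compounds named here, the only step available, from compound 1 to compound 2, concerns trifluoromethyl in place of hydrogen on an aromatic carbon and therefore bears on it only indirectly: it shows that a substituted phenyl on that amide-type nitrogen gives a far lower number than the unsubstituted phenyl of compound 1. Compound 3 keeps a substituted phenyl there, so the expectation is a number near that of compound 2, with a step of a number 18.3 percentage points higher from compound 2 to compound 3 (beyond the scatter) expected to lie within or close to the scatter rather than a return toward compound 1.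

Estimate for compound 3 in this assay: 10%, expected range -15% to 45%.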

Compound 3, a percentage reported as activity, at one concentration (the size of the read-out at that concentration, not a potency): 47.8%
Estimate against measurement, compound 3: 37.8 percentage points below, and the stated range ends below it.
By their numbers in this assay, from the lowest: compound 2; then compound 3; then compound 1.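

In this assay the change from phenyl to 3,4-dichlorophenyl on the amide-type nitrogen gives a number 32.2 percentage points lower from compound 1 to compound 3 (beyond the scatter) as a second substituted case, so a lower number than that of the unsubstituted phenyl is no longer tied to trifluoromethyl alone. The choice of substituted phenyl still matters: 3,4-dichlorophenyl in place of 3-(trifluoromethyl)phenyl gives a number 56.1 percentage points higher from compound 2 to compound 3 (beyond the scatter) and leaves compound 3 in the middle of the three, so substitution at this place does not by itself reach the low number of compound 2. This place therefore separates two substituted phenyls from each other, and not only substituted from unsubstituted, a reading that rests on these three compounds only.

Open, as far as these compounds go, is where a phenyl carrying a single chlorine, a methoxy group or an amine would fall at this place, and whether the order of the three holds at other concentrations. Nothing on hand accounts for the difference between the trifluoromethyl and dichloro compounds.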